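The source may report more compounds than this note shows. Statements on the series, on what has been measured and on what is new or still open speak of the compounds shown alone.

Measured so far:
Compound 1 `OC1CC2(CCNCC2)Oc2c1ccc1ccccc21` gives <= 10000 nM in a physicochemical assay for solubility, read by HPLC, at pH 6.5; a higher number here means a more soluble compound, a lower number a less soluble compound.
Compound 2 `O=C1CC2(CCNCC2)Oc2c1ccc1ccccc21` gives >= 80000 nM in this assay.

For compound 1 the reading is a limit of the assay rather than a number: the limit of <= 10000 nM in this assay, at which 1 of the 2 values shown sits. Among the compounds with values here, for compound 2 the reading is also a limit rather than a number, (the limit of >= 80000 nM in this assay, at which 1 of the 2 values shown sits), so compound 2 stands at the upper edge of what this assay reports, while the only other value shown sits at the lower edge. Compound 3 `CCN1CCC2(CC1)CC(=O)c1ccc3ccccc3c1O2` has not been measured yet. It differs from compound 2 in one place: ethyl in place of hydrogen on an amine nitrogen in a ring. Within the data shown here, no measured step shows what this change does to solubility. The step of an at least 1.1-fold lower number from compound 2 to compound 3 (0.05 log units; that floor lies within the scatter) is expected to be small, possibly slightly downward, and not clearly beyond the usual scatter. Compound 3 is therefore estimated at 70000 nM, between 20000 nM and 160000 nM, with a real chance that only a limit is reported again.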

Compound 3, solubility: >= 80000 nM
Compound 3 ended at the assay's limit; the forecaster's own chance of this, stated with the estimate: 45%; at least 1.1-fold (0.05 log units) between middle value and limit.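

Compound 2 and compound 3 both read at the upper limit of this assay, so no step can be read between them. The compounds shown leave open whether ethyl in place of hydrogen on the amine nitrogen in a ring changes solubility at all.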